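Nitro for nitrile on two androgen-receptor-type scaffolds

A few compounds are considered here, and "the series" means these few. Any claim that something is new, unique, unknown or untested is made for them only; others in the source may bear on it.

Measured compounds:
compound 1 `CC(O)(CSc1cc(C(F)(F)F)cc(C(F)(F)F)c1)C(=O)Nc1ccc(C#N)cc1C(F)(F)F` — 7760 nM
compound 2 `CC(O)(CSc1cc(C(F)(F)F)cc(C(F)(F)F)c1)C(=O)Nc1ccc([N+](=O)[O-])cc1C(F)(F)F` — 3110 nM
compound 3 `CC1(C)C(=O)N(c2ccc(C#N)cc2C(F)(F)F)C(=S)N1c1cc(C(F)(F)F)cc(C(F)(F)F)c1` — "nd(insoluble)" (no result reported)

In a functional assay on LNCaP cells (Homo sapiens) for antiproliferative activity, read by fluorescence and propidium iodide staining, with a stated time of 96 h (on this read-out higher numbers stand for weaker inhibition and lower numbers for stronger inhibition), compound 1 gives 7760 nM and compound 2 gives 3110 nM. The change between them is nitro in place of cyano on an aromatic carbon, and it produced a 2.5-fold lower number from compound 1 to compound 2 (0.40 log units; beyond the scatter). Compound 3 `CC1(C)C(=O)N(c2ccc(C#N)cc2C(F)(F)F)C(=S)N1c1cc(C(F)(F)F)cc(C(F)(F)F)c1` carries a different core; how it differs from the core of compound 1 is not broken down here. In this assay compound 3 gives "nd(insoluble)" (no result reported), which is no number. Compound 4 `CC1(C)C(=O)N(c2ccc([N+](=O)[O-])cc2C(F)(F)F)C(=S)N1c1cc(C(F)(F)F)cc(C(F)(F)F)c1` stands to compound 3 as compound 2 stands to compound 1: the change is nitro in place of cyano on an aromatic carbon, the same change as before, at the same place. Going by the values given here, no step can be computed for compound 4, since compound 3 has no value. The expectation therefore rests only on the open-chain pair, compound 1 to compound 2, with a 2.5-fold lower number from compound 1 to compound 2 (0.40 log units; beyond the scatter) as a guide, and on the risk that compound 4, like compound 3, returns no number. Compound 4 is estimated at 2000 nM in this assay, with a wide range from 300 nM to 15000 nM.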

Compound 4, half-maximal inhibitory concentration: 4670 nM
Compound 4: the middle estimate sits 2.3-fold (0.37 log units) below what was measured, and the stated range covers the measured number.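

No step can be read from compound 3 to compound 4 in this assay: compound 3 has no number there. From the compounds shown here alone, whether nitro in place of cyano does the same on both cores stays open. No evidence on this is available.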